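The source may report more compounds than this note shows. Statements on the series, on what has been measured and on what is new or still open speak of the compounds shown alone.

Compound 1 `ClCc1cccc(Cn2cnc3c(Cl)ncnc32)c1` is the starting point of this set. In a functional assay on NCI-H460 cells (Homo sapiens) for cytotoxicity, read by sulforhodamine B assay, with a stated time of 48 h (on this read-out lower numbers stand for stronger inhibition of growth and higher numbers for weaker inhibition of growth), compound 1 gives 36300 nM. Compound 2 `ClCc1cccc(Cn2cnc3c(Cl)nc(Cl)nc32)c1` carries one change from compound 1, namely (chloro in place of hydrogen on an aromatic carbon). In this assay compound 2 gives 6310 nM, and the step of a 5.8-fold lower number from compound 1 to compound 2 (0.76 log units; beyond the scatter) is recorded. Compound 3 `ClCc1ccccc1Cn1cnc2ncnc(Cl)c21` is made of the same atoms as compound 1 joined differently; the difference between the two cores is not broken down here. In this assay compound 3 gives 60300 nM, a number that lies within the usual scatter of the value of compound 1 and beyond the scatter of the value of compound 2. Compound 4 `ClCc1ccccc1Cn1cnc2nc(Cl)nc(Cl)c21` has not yet been measured. It differs from compound 3 by chloro in place of hydrogen on an aromatic carbon, the same change that separates compound 1 from compound 2, at a place described in the same words. Compound 4 is expected to show a step of similar size, a 5.5-fold lower number from compound 3 to compound 4 (0.74 log units; beyond the scatter), because the earlier step of a 5.8-fold lower number from compound 1 to compound 2 (0.76 log units; beyond the scatter) was modest yet beyond the scatter. On that basis compound 4 is estimated to give 11000 nM in this assay, with a likely range from 4000 nM to 30000 nM. This expectation rests on a single earlier pair only.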

Compound 4, concentration for total growth inhibition: 5880 nM
Compound 4: the middle estimate sits 1.9-fold (0.27 log units) above what was measured; measured number inside the range.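

On the core of compound 3, chloro in place of hydrogen on an aromatic carbon, between two ring nitrogen atoms, again goes with stronger inhibition of growth in this assay (a 10-fold lower number from compound 3 to compound 4 (1.01 log units; beyond the scatter)). Set beside the earlier step on the core of compound 1, the size of the change carries over within the scatter: the same change on two cores in this assay, a 5.8-fold lower number (0.76 log units; beyond the scatter) from compound 1 to compound 2 and a 10-fold lower number (1.01 log units; beyond the scatter) from compound 3 to compound 4, 1.8-fold (0.25 log units) apart, within the scatter of two such steps. This shows that the change keeps its direction and a comparable size on these two cores, but it rests on two pairs only, so it does not show that the second step is truly the larger, why the number falls, or that the same would hold on any further core.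

On these data alone, whether an amine or a methoxy group on that same carbon would go the same way as chloro remains open. As far as these compounds go, whether the step would persist in other cell lines also remains open.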